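Cinnamate glycolamide series: a furan-to-thiazole swap

The source may hold more compounds than are shown below. What is called first, only, known or untested is meant among the compounds shown, and "the series" means these compounds.

Working notes on a small set of cinnamate esters and amides. Compound 1 `COc1ccc(/C=C/C(=O)OCC(=O)Nc2ccccc2)cc1OC` gives 46400 nM in a functional assay on HL-60 cells (Homo sapiens) for cytotoxicity, read by MTT assay, with a stated time of 72 h; a lower number here means a stronger inhibitor, a higher number a weaker inhibitor. Compound 2 `COCOc1cc(/C=C/C(=O)OCC(=O)NCc2ccco2)ccc1OCc1ccccc1` gives 82200 nM in this assay, and of the two numbers shown it is the higher, though its gap to compound 1 lies within the scatter, so no order between these two can be read. Compound 3 `CCOc1ccc(COc2c(OC)cc(/C=C/C(=O)N3CCN(Cc4ccc(Cl)c(Cl)c4)CC3)cc2OC)cc1` returns only a limit in this assay, namely > 200000 nM. That result is the limit of > 200000 nM in this assay, at which 1 of the 3 values shown sits. Compound 4 `COCOc1cc(/C=C/C(=O)OCC(=O)Nc2nccs2)ccc1OCc1ccccc1` is the next member to be tested and differs from compound 2 by 1,3-thiazol-2-yl in place of (furan-2-yl)methyl on an amide-type nitrogen. Among the compounds with values here, no pair of measured compounds differs in one place, so no measured step is available to anchor the change, and all three measured values sit in the weak range. The step from compound 2 to compound 4 is expected to be small, a 1.2-fold lower number from compound 2 to compound 4 (0.07 log units; within the scatter), and not beyond the scatter. Compound 4 is estimated at 70000 nM, with a range from 30000 nM to 180000 nM.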

Compound 4, half-maximal inhibitory concentration: > 200000 nM
Compound 4 gave a limit, no number; the forecaster's own chance of this, stated with the estimate: 20%; at least 2.8-fold (0.45 log units) between middle value and limit.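

Within the data shown here, this is the first one-place step. On the amide-type nitrogen, 1,3-thiazol-2-yl in place of (furan-2-yl)methyl gives an at least 2.4-fold higher number from compound 2 to compound 4 (0.38 log units; beyond the scatter) in this assay, so this position is not indifferent to the change. Compound 4 gives > 200000 nM as a limit and not a number, so the step has a lower bound but no measured size, and the limit now recurs in the set: the limit of > 200000 nM in this assay, at which 2 of the 4 values shown sit.

The step changes the ring and removes the methyl link in one move, and the compounds shown do not separate these two parts. A (1,3-thiazol-2-yl)methyl group on the same nitrogen would sit between compound 2 and compound 4 and could assign the step to one part or the other.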